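A few compounds are considered here, and "the series" means these few. Any claim that something is new, unique, unknown or untested is made for them only; others in the source may bear on it.

Measured so far in a functional assay on B16-F10 cells (Mus musculus) for inhibition, read by MTT assay, with a stated time of 72 h; a higher number here means a weaker inhibitor, a lower number a stronger inhibitor: compound 1 `CC1(C)CC(NC(=S)Nc2ccc([N+](=O)[O-])cc2)c2cc(Cl)ccc2O1` gives 3000 nM; compound 2 `CC1(C)CC(NC(=S)Nc2ccc([N+](=O)[O-])cc2)c2cc(F)ccc2O1` gives 4000 nM; compound 3 `CC1(C)CC(NC(=S)Nc2cccc([N+](=O)[O-])c2)c2cc(Cl)ccc2O1` gives 6000 nM. All three numbers lie within the scatter of one another, so none can be set apart as the strongest or weakest inhibitor.

Compound 1 and compound 2 differ by one change, (fluoro in place of chloro on an aromatic carbon), and the result was a 1.3-fold higher number from compound 1 to compound 2 (0.12 log units; within the scatter). Compound 3 is built on a core that differs from that of compound 1; the difference between the two cores is not broken down here. Compound 4 `CC1(C)CC(NC(=S)Nc2cccc([N+](=O)[O-])c2)c2cc(F)ccc2O1` carries the same change relative to compound 3, (fluoro in place of chloro on an aromatic carbon), at the same place as in the earlier pair.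

Because the earlier step, a 1.3-fold higher number from compound 1 to compound 2 (0.12 log units; within the scatter), stayed within the scatter, only a small shift is expected for compound 4, about a 1.3-fold higher number from compound 3 to compound 4 (0.10 log units; within the scatter). Compound 4 is therefore estimated in this assay at 7500 nM, with a likely range from 3500 nM to 16000 nM.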

Compound 4, half-maximal inhibitory concentration: 6000 nM
For compound 4 the middle estimate is 1.3-fold (0.10 log units) above the measured one; the range from low to high includes it.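

In this assay, fluoro in place of chloro on an aromatic carbon gave no change at the digits printed from compound 3 to compound 4 (within the scatter). Set beside the earlier pair, the change carried from one core to the other with no difference that can be told apart: the same change on two cores in this assay, a 1.3-fold higher number (0.12 log units; within the scatter) from compound 1 to compound 2 and no change at the digits printed (within the scatter) from compound 3 to compound 4, 1.3-fold (0.12 log units) apart, within the scatter of two such steps This shows only that the step stayed within the scatter on both cores; it does not show that chloro and fluoro are interchangeable on any other core in this series.

The compounds shown leave open whether another group on that aromatic carbon, such as methoxy, trifluoromethyl or an amine, would move the number beyond the scatter. They also leave open what a nitrile or a carboxylic acid in place of the nitro group would do.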